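This account rests on a few compounds, and the source may have more. Where it says the series, first, only, none or still open, it means among the compounds named here.

Working notes on the series in a functional assay on MDA-MB-231 cells (Homo sapiens) for antiproliferative activity, read by MTT assay, with a stated time of 72 h; on this read-out higher numbers stand for weaker inhibition and lower numbers for stronger inhibition. Compound 1 `COc1cc(-c2nccn2C(C)C)cc(OC)c1OC` gives > 100000 nM, which is a limit of the assay and not a number. Compound 2 `COc1cc(-c2nccn2S(=O)(=O)c2ccccc2)cc(OC)c1OC` gives > 100000 nM, also a limit. Compound 3 `COc1cc(-c2nccn2-c2cccc([N+](=O)[O-])c2)cc(OC)c1OC` gives > 100000 nM, again a limit. Among the compounds with values here, compound 1 therefore stands at the limit of > 100000 nM in this assay, at which 3 of the 3 values shown sit, and the series so far offers no measured number to rank it against.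

Compound 4 `COc1cc(-c2nccn2-c2ccc(F)cc2)cc(OC)c1OC` keeps the core of compound 1 and carries 4-fluorophenyl in place of isopropyl on an aromatic nitrogen. Within the data shown here, no step between measured compounds is available to size this change. With compound 3 reading > 100000 nM as a limit, the expectation is no step beyond the usual scatter in this assay, and any shift that does appear is expected toward stronger inhibition. The expected move is an at least 1.2-fold lower number from compound 1 to compound 4 (0.09 log units; that floor lies within the scatter). Compound 4 is estimated at 80000 nM, with an expected range of 25000 nM to 150000 nM.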

Compound 4, half-maximal inhibitory concentration: 38400 nM
For compound 4 the middle estimate is 2.1-fold (0.32 log units) above the measured one, within the range that was stated.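

In this assay, within the data shown here, the aromatic nitrogen now yields a measured number for the first time: 4-fluorophenyl in place of isopropyl gives an at least 2.6-fold lower number from compound 1 to compound 4 (0.41 log units; beyond the scatter). On these data alone, compound 1 gives a limit and not a number, so this step is only a floor and its full size stays unknown. Compound 3, which also carries an aromatic ring on that nitrogen, gives > 100000 nM, a limit of the assay, so an aromatic ring at this position does not by itself bring a measurable value.

Still open, as far as these compounds go, is whether the fluorine or the phenyl ring accounts for the step, which a plain phenyl, a 4-methoxyphenyl or a phenyl ring carrying an amine would help to settle. Ranking across the series also remains out of reach, with most values at a limit: the limit of > 100000 nM in this assay, at which 3 of the 4 values shown sit.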